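Cytotoxicity notes: acetyl replacing phenyl on the shared core

The source may report more compounds than this note shows. Statements on the series, on what has been measured and on what is new or still open speak of the compounds shown alone.

The series shares one core, seen in compound 1 `CCOC(=O)c1c(-c2cccc(C)c2)[nH]c2cc(OC)ccc2c1=O`, compound 2 `CCOC(=O)c1c(-c2cccc(-c3ccccc3)c2)[nH]c2cc(OC)ccc2c1=O` and compound 3 `CCOC(=O)c1c(-c2cccc(OC(F)(F)F)c2)[nH]c2cc(OC)ccc2c1=O`. In an ADME assay on HEK293 cells (Homo sapiens) for cytotoxicity, read by luminescence, with a stated time of 72 h (a lower number here means that less compound is needed, a higher number that more compound is needed for the effect), compound 1 gives only a limit, > 22000 nM. Compound 2 likewise reaches only a limit in this assay, > 22000 nM. Compound 3 also stops at a limit, > 22000 nM. All three sit at one limit, (the limit of > 22000 nM in this assay, at which 3 of the 3 values shown sit), so the steps a step that the two limits leave unreadable from compound 1 to compound 2, a step that the two limits leave unreadable from compound 1 to compound 3 and a step that the two limits leave unreadable from compound 2 to compound 3 have no readable size. Compound 4 `CCOC(=O)c1c(-c2cccc(C(C)=O)c2)[nH]c2cc(OC)ccc2c1=O` is not yet measured; it differs from compound 2 by acetyl in place of phenyl on an aromatic carbon. Among the compounds with values here, no measured step bears on this change with a readable size. The expected step that the limit leaves unreadable from compound 2 to compound 4 is none beyond the scatter. Compound 4 is estimated at 30000 nM, in a range from 12000 nM to 80000 nM, most likely reported again as a limit.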

Compound 4, half-maximal effective concentration: > 22000 nM
Compound 4 ended at the assay's limit; the forecaster's own chance of this, stated with the estimate: 80%; the middle value lies beyond the limit too.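

No step from compound 1, compound 2 or compound 3 to compound 4 can be read in this assay, as all four values are limits: the limit of > 22000 nM in this assay, at which 4 of the 4 values shown sit.

The compounds shown leave open whether methyl, phenyl, trifluoromethoxy and acetyl differ at all in this assay.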